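A few compounds are considered here, and "the series" means these few. Any claim that something is new, unique, unknown or untested is made for them only; others in the source may bear on it.

Compound 1 `CSc1cccc(NC(=O)CN2CCC(c3cccc[n+]3[O-])CC2)c1`: 100 nM
Compound 2 `CC(C)Oc1cccc(NC(=O)CN2CCC(c3cccc[n+]3[O-])CC2)c1`: 555 nM
Compound 3 `CCc1cccc(NC(=O)CN2CCC(c3cccc[n+]3[O-])CC2)c1`: 95 nM

These three compounds share one core and differ only in a single group on an aromatic carbon. In a functional assay on HEK293 cells for agonist activity at D(4) dopamine receptor (Homo sapiens), read by FLIPR (on this read-out higher numbers stand for an effect only at larger amounts of compound and lower numbers for an effect already at smaller amounts), compound 3 has the lowest number of the three, but that says little against compound 1, since the step between them is small: a 1.1-fold lower number from compound 1 to compound 3 (0.02 log units; within the scatter). Among the measured compounds shown here, the one clear step in the set is a 5.8-fold lower number from compound 2 to compound 3 (0.77 log units; beyond the scatter), which matches a 5.6-fold higher number from compound 1 to compound 2 (0.74 log units; beyond the scatter) seen from the other side.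

Compound 4 `O=C(CN1CCC(c2cccc[n+]2[O-])CC1)Nc1cccc(OC(F)(F)F)c1` has not yet been measured. (trifluoromethoxy in place of ethyl on an aromatic carbon). For the measured compounds named here, no measured step involves trifluoromethoxy, so any expectation rests on analogy. Ethyl and methylsulfanyl gave numbers within the scatter of each other, whereas isopropoxy gave a modestly higher number. Trifluoromethoxy, like isopropoxy, is joined to the ring through an oxygen, so a modest rise in this assay seems somewhat more likely than a fall, though the support for this is thin. For compound 4 the expected step is a 2.6-fold higher number from compound 3 to compound 4 (0.42 log units; beyond the scatter). Compound 4 is therefore estimated at 250 nM in this assay, with a range from 80 nM to 800 nM.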

Compound 4, half-maximal effective concentration: 135 nM
Estimate against measurement, compound 4: 1.9-fold (0.27 log units) above; the measured number falls inside the stated range.
By their numbers in this assay, from the lowest: compounds 3, 1 and 4 (each within the scatter of the next); then compound 2.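

In this assay, joining a group to the ring through an oxygen does not by itself go with a higher number, since trifluoromethoxy stands level with ethyl (a 1.4-fold higher number from compound 3 to compound 4 (0.15 log units; within the scatter)) and with methylsulfanyl (a 1.4-fold higher number from compound 1 to compound 4 (0.13 log units; within the scatter)). What sits on that oxygen does matter here: with trifluoromethyl in place of isopropyl, the number drops clearly (a 4.1-fold lower number from compound 2 to compound 4 (0.61 log units; beyond the scatter)), so compound 2 stands apart while the other three compounds, with quite different groups at this place, cannot be told apart in this read-out. Nothing available here accounts for why the isopropoxy compound alone stands apart.

The compounds shown leave open what a plain methoxy or a longer chain such as butoxy would give at this place, which would help show whether compound 2 is a lone case or part of a trend, and the same holds for an amine or a carboxylic acid. They also leave open how these groups would behave on another carbon of the ring, and how fully each compound switches the receptor on, since the half-maximal concentration alone does not tell that.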